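The source may hold more compounds than are shown below. What is called first, only, known or untested is meant among the compounds shown, and "the series" means these compounds.

Compound 3 `FC(F)OCCc1ccccc1` carries a difluoromethoxy group on a two-carbon chain attached to a benzene ring. In a physicochemical assay for lipophilicity, read by spectrophotometry, using the shake flask method, measured as octanol-water partition (on this read-out lower numbers stand for lower lipophilicity and higher numbers for higher lipophilicity), compound 3 gives 3.16, the highest of the three values known here. Compound 1 `Cc1ccc(C(F)F)cc1` gives 2.94 in this assay, a value within the scatter of that of compound 3, so no order between the two is claimed. Compound 2 `O=[N+]([O-])c1ccc(S(=O)(=O)C(F)F)cc1` gives 1.7 in this assay, well beyond the scatter below compound 3.

Compound 4 `COCCc1ccccc1` is yet to be measured. It differs from compound 3 in one place: methyl in place of difluoromethyl on an oxygen on a saturated carbon. Among the compounds with values here, no measured pair shows the effect of this change. Compound 4 is expected to fall beyond the scatter below compound 3, with an estimated step of a number 0.56 log units lower from compound 3 to compound 4 (beyond the scatter). Compound 4 is estimated at 2.6, in a range from 2.2 to 3.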

Compound 4, partition coefficient: 2.23
For compound 4 the middle estimate is 0.37 log units above the measured one, and the stated range covers the measured number.
By their numbers in this assay, from the lowest: compound 2; then compound 4; then compounds 1 and 3 (each within the scatter of the next).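

Within the data shown here, the pair gives the only direct reading here of methyl in place of difluoromethyl on an oxygen on a saturated carbon: in this assay this change gives a number 0.93 log units lower from compound 3 to compound 4 (beyond the scatter) and thus shows that the two groups are not interchangeable at this place. The earlier compounds shown here, which differ in more than one place, could not show this. Nothing measured here accounts for the size of the step.

The compounds shown leave open how trifluoromethyl on the same oxygen would read. They also leave open whether the difluoromethoxy to methoxy step would hold on a longer chain.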